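Replacing 2-fluorophenyl in compound 3

The source may report more compounds than this note shows. Statements on the series, on what has been measured and on what is new or still open speak of the compounds shown alone.

Values measured in an ADME assay on L02 cells (Homo sapiens) for cytotoxicity, read by MTT assay, with a stated time of 24 h; on this read-out lower numbers stand for stronger inhibition and higher numbers for weaker inhibition:
compound 1 `COc1ccc(/C=C2\CN(C)C/C(=C\c3ccccc3F)C2=O)cc1OC` gives 10500 nM
compound 2 `COc1cc(/C=C2\CN(C)C/C(=C\c3ccccc3F)C2=O)cc(OC)c1` gives 11900 nM
compound 3 `COc1cc(/C=C2\CN(C)C/C(=C\c3ccccc3F)C2=O)cc(OC)c1OC` gives 12100 nM

Compound 3 stands level with the other two compounds, as the two steps leading to it show: a 1.2-fold higher number from compound 1 to compound 3 (0.06 log units; within the scatter) and a 1.0-fold higher number from compound 2 to compound 3 (0.01 log units; within the scatter). Compound 4 `COc1cc(/C=C2\CN(C)C/C(=C\c3cc(OC)c(OC)c(OC)c3)C2=O)cc(OC)c1` has not yet been measured. It has 3,5-dimethoxyphenyl in place of 2-fluorophenyl on a double-bonded chain carbon bound to a double-bonded ring carbon, and the counted difference is 3,5-dimethoxyphenyl in place of 2-fluorophenyl on a double-bonded chain carbon bound to a double-bonded ring carbon. For the measured compounds named here, no measured step makes this replacement. The two steps above are the nearest evidence, but each adds a methoxy in place of hydrogen on the other aromatic ring, which stays the same here. Neither moved the number in this assay beyond the scatter, so no step beyond the scatter is expected, in either direction. That expectation is loose, since the data do not show what removing the fluorine does. The estimated step is a 1.1-fold higher number from compound 3 to compound 4 (0.03 log units; within the scatter). Compound 4 is expected at 13000 nM, with an estimated range from 6000 nM to 28000 nM.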

Compound 4, half-maximal inhibitory concentration: 14600 nM
Beside the measured number, compound 4's estimate is 1.1-fold (0.05 log units) below it; the measured number falls inside the stated range.
By their numbers in this assay, from the lowest: compounds 1, 2, 3 and 4 (each within the scatter of the next).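

In this assay the exchange of 2-fluorophenyl for 3,5-dimethoxyphenyl on a double-bonded chain carbon bound to a double-bonded ring carbon gives a 1.2-fold higher number from compound 3 to compound 4 (0.08 log units; within the scatter) and so stays inside the usual spread of repeats. The earlier compounds shown here all carried 2-fluorophenyl at this place and could say nothing about it, whereas this pair shows that the fluorine can be lost, and a group with more heavy atoms and with hydrogen-bond acceptors can enter, without a step beyond the scatter. Nothing on hand accounts for this result. Going by these compounds, this rests on a single replacement at this place, so it remains open whether the number would also hold with an amine or a carboxylic acid on the aromatic ring there. On these data alone, whether a plain unsubstituted phenyl or a longer chain in that place would behave the same also remains open.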